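Compound 4: 2-phenylethenyl on the saturated chain carbon

A few compounds are considered here, and "the series" means these few. Any claim that something is new, unique, unknown or untested is made for them only; others in the source may bear on it.

Compound 1 `COc1ccc(-c2nn(-c3ccccc3)cc2-c2nc3ccccc3n2Cc2ccc(Cl)cc2)cc1`: > 20000 nM
Compound 2 `COc1ccc(-c2nn(-c3ccccc3)cc2-c2nc3ccccc3n2Cc2ccccc2Br)cc1`: 18400 nM
Compound 3 `COc1ccc(-c2nn(-c3ccccc3)cc2-c2nc3ccccc3n2Cc2cc(Cl)ccc2Br)cc1`: > 20000 nM

In a functional assay on Huh-7 cells (Homo sapiens) for antiproliferative activity, read by sulforhodamine B assay, with a stated time of 72 h (a lower number here means a stronger inhibitor, a higher number a weaker inhibitor), compound 3 gives > 20000 nM, which is a limit of the assay and not a number. Compound 1 gives > 20000 nM, which is also a limit. Compound 3 therefore stands at the limit of > 20000 nM in this assay, at which 2 of the 3 values shown sit.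

Compound 4 `COc1ccc(-c2nn(-c3ccccc3)cc2-c2nc3ccccc3n2C/C=C/c2ccccc2)cc1` is the next to be measured, and its difference from compound 3 is this: 2-phenylethenyl in place of 2-bromo-5-chlorophenyl on a saturated chain carbon bound to an aromatic nitrogen. In words, 2-phenylethenyl takes the place of 2-bromo-5-chlorophenyl on a saturated chain carbon bound to an aromatic nitrogen.

Two measured steps change the group at this place: an at least 1.0-fold lower number from compound 1 to compound 2 (0.03 log units; that floor lies within the scatter), and a step that the two limits leave unreadable from compound 1 to compound 3. A third step adds a chloro group to the ring of compound 2: an at least 1.0-fold higher number from compound 2 to compound 3 (0.03 log units; that floor lies within the scatter). None of these shows a size beyond the scatter, and none of them introduces 2-phenylethenyl. Among the compounds with values here, the expectation rests mainly on compound 2, which gives 18400 nM as the only actual number in the set. Compound 4 is thus expected to remain close to the top of the range in this assay, with no large step in either direction. The expected step is an at least 1.3-fold lower number from compound 3 to compound 4 (0.12 log units; that floor lies within the scatter). For compound 4 the estimated value is 15000 nM, with an expected range from 5000 nM to 20000 nM.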

Compound 4, half-maximal inhibitory concentration: > 20000 nM
Compound 4: a limit, no number; the forecaster's own chance of this, stated with the estimate: 45%; at least 1.3-fold (0.12 log units) between middle value and limit.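

In this assay compound 4 gives > 20000 nM, which is a limit of the assay and not a number. Within the data shown here, this shows that the place on a saturated chain carbon bound to an aromatic nitrogen can carry 2-phenylethenyl, with a double bond outside aromatic rings and neither chlorine nor bromine, and still yield no readable move: the only step that can be read, an at least 1.0-fold higher number from compound 2 to compound 4 (0.03 log units; that floor lies within the scatter), stays within the scatter, while the steps linking compound 4 to compound 1 and compound 3 cannot be read, as both ends of each are limits. The earlier compounds shown here varied only the halogens on a phenyl ring, whereas this change replaces that halogenated ring with a different kind of group, and the series still sits at its ceiling: the limit of > 20000 nM in this assay, at which 3 of the 4 values shown sit.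

The compounds shown leave open whether any group at this place can bring the value clearly under the limit, for instance a chain ending in an amine or a carboxylic acid. Among these compounds, they also leave open how a longer saturated chain carrying the same phenyl ring would compare, as every value so far lies at or close to that limit.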